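The source may report more compounds than this note shows. Statements on the series, on what has been measured and on what is new or still open speak of the compounds shown alone.

Working notes on the series.

Compound 3 `O=C(I)NCC(=O)NCCCCCCNc1ncnc2c1ncn2[C@@H]1O[C@H](COP(=O)(O)OP(=O)(O)OP(=O)(O)O)[C@@H](O)[C@H]1O` gives 0% in an assay on isolated protein for inhibition of hexokinase-2 (Rattus norvegicus), with a stated time of 6 h, tested at 10 mM; on this read-out higher numbers stand for more inhibition at the one concentration tested (going by the name of the read-out) and lower numbers for less inhibition. Compound 1 `O=C(CI)NCCCC(=O)NCCCCCCNc1ncnc2c1ncn2[C@@H]1O[C@H](COP(=O)(O)OP(=O)(O)OP(=O)(O)O)[C@@H](O)[C@H]1O` gives 0% in this assay, and compound 2 `O=C(CI)NCCCCCCC(=O)NCCCCCCNc1ncnc2c1ncn2[C@@H]1O[C@H](COP(=O)(O)OP(=O)(O)OP(=O)(O)O)[C@@H](O)[C@H]1O` gives 0%, so compound 3 stands level with both at the digits reported.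

Compound 4 `O=C(CI)NCCCCCC(=O)NCCCCCCNc1ncnc2c1ncn2[C@@H]1O[C@H](COP(=O)(O)OP(=O)(O)OP(=O)(O)O)[C@@H](O)[C@H]1O` differs from compound 3 at one place: a group of 9 heavy atoms (6 carbon, 1 nitrogen, 1 oxygen, 1 iodine; no ring) in place of a group of 4 heavy atoms (1 carbon, 1 nitrogen, 1 oxygen, 1 iodine; no ring), on a saturated chain carbon bound to a carbonyl carbon.

Three measured steps change the same part of the chain. The step of no change at the digits printed from compound 1 to compound 3 (within the scatter) and the step of no change at the digits printed from compound 2 to compound 3 (within the scatter) each swap the group on the saturated chain carbon bound to a carbonyl carbon without moving the read-out, and the step of no change at the digits printed from compound 1 to compound 2 (within the scatter) likewise shows nothing beyond the scatter. Within the data shown here, no measured step at this position has moved the read-out, so no step beyond the scatter is expected for compound 4 in this assay.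

Compound 4 is therefore expected at 0%, with a range of 0% to 10%, an expected step of no change at the digits printed from compound 3 to compound 4 (within the scatter).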

Compound 4, a percentage reported as inhibition, at one concentration (the size of the read-out at that concentration, not a potency): 0%
For compound 4 middle estimate and measured number coincide at the digits printed, within the range that was stated.
By their numbers in this assay, from the lowest: compounds 1, 2, 3 and 4 (each within the scatter of the next).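

In this assay the series shows no change at the digits printed from compound 3 to compound 4 (within the scatter), and equally no change at the digits printed from compound 2 to compound 4 (within the scatter) and no change at the digits printed from compound 1 to compound 4 (within the scatter). 4-(((iodomethyl)carbonyl)amino)butyl therefore adds one more chain length to the flat set, and the four compounds give no ranking by chain length. Nothing at hand offers an explanation for this flat result.

Going by these compounds, whether a longer chain, or an amine or carboxylic acid in place of the iodine-bearing end, would give any inhibition stays open. With every reading level, the compounds shown do not tell which parts of the structure matter for this read-out.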